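The source may hold more compounds than are shown below. What is called first, only, known or untested is meant among the compounds shown, and "the series" means these compounds.

Compound 3 `CCN(CC)Cc1cnc2c(CNC(=O)c3ccc(-c4ccc(F)cc4)nc3)cccc2c1` belongs to a small set of amides examined in an assay on isolated protein for binding affinity to melanin-concentrating hormone receptor 1 (Homo sapiens), read by radioligand binding; a lower number here means a stronger inhibitor, a higher number a weaker inhibitor. In this assay compound 3 gives 310 nM. Going by the values given here, compound 2 `CN(C)Cc1cnc2c(CNC(=O)c3ccc(-c4ccc(F)cc4)nc3)cccc2c1` gives 414 nM in this assay, and the single change between them, a 1.3-fold lower number from compound 2 to compound 3 (0.13 log units; within the scatter), is too small to count as a real shift. Compound 1 `CS(=O)(=O)C1CCN(Cc2cnc3c(CNC(=O)c4ccc(-c5ccc(F)cc5)cc4)cccc3c2)CC1` differs from compound 3 in two places; in this assay compound 1 gives 310 nM, so compound 3 and compound 1 stand level with each other, and together they hold the lowest numbers among the three.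

Compound 4 `O=C(NCc1cccc2cc(CN3CCC(O)CC3)cnc12)c1ccc(-c2ccc(F)cc2)nc1` has not yet been measured. It differs from compound 3 in one place: 4-hydroxypiperidin-1-yl in place of diethylamino on a saturated chain carbon bound to an aromatic carbon. Among the compounds with values here, the only measured step at the same place is a 1.3-fold lower number from compound 2 to compound 3 (0.13 log units; within the scatter), which stayed within the scatter, and compound 1 shows that a different ring amine at this position, with a different amide, still gave 310 nM. On that basis no step beyond the scatter is expected, and the change from compound 3 to compound 4 is estimated at a 1.0-fold lower number from compound 3 to compound 4 (0.01 log units; within the scatter). Compound 4 is therefore expected to give about 300 nM in this assay, with a likely range from 120 nM to 750 nM.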

Compound 4, inhibition constant: 803 nM
The estimate for compound 4 lay 2.7-fold (0.43 log units) below the measured number; the whole stated range lies below it.
By their numbers in this assay, from the lowest: compounds 1, 3, 2 and 4 (each within the scatter of the next, the first and the last beyond it).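

In this assay, going by these compounds alone, the group on the saturated chain carbon bound to an aromatic carbon proves able to move the number: 4-hydroxypiperidin-1-yl in place of diethylamino gives a 2.6-fold higher number from compound 3 to compound 4 (0.41 log units; beyond the scatter), the first step at this place to pass beyond the scatter. In place of dimethylamino, the same group gives a 1.9-fold higher number from compound 2 to compound 4 (0.29 log units; within the scatter), so it stands clearly apart from only one of the two amines without a ring, and the size of the change depends on the amine it replaces. Nothing measured here explains the higher number.

This change brings in a ring and a hydroxyl together, so the compounds shown cannot separate the two. A plain piperidin-1-yl at this place, with the ring but no hydroxyl, is the comparison that could tell them apart.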